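From propylamino to methylsulfanyl under a cytotoxicity limit

The compounds below may be only part of what the source reports. "The series", "measured", "known", "first", "only" and "open" are said of these compounds alone.

Compound 1 `CC(C)CSc1nc(N)nc2c1ncn2/C=C1/CC1(CO)CO`: > 20000 nM
Compound 2 `CCCNc1nc(N)nc2c1ncn2/C=C1/CC1(CO)CO`: > 24000 nM
Compound 3 `CSc1nc(N)nc2c1ncn2/C=C1/CC1(CO)CO`: not yet measured

All three compounds are judged in an ADME assay on Akata cells (Homo sapiens) for cytotoxicity, with a stated time of 7 days; a higher number here means that more compound is tolerated, a lower number that less compound is tolerated. Compound 2 reads > 24000 nM, which is a limit of the assay and not a number. Compound 1 reads > 20000 nM, which is also a limit. Neither compound therefore has an exact tolerated concentration, and neither can be ranked against the other.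

The next change is methylsulfanyl in place of propylamino on an aromatic carbon. In words, it puts methylsulfanyl in place of propylamino on an aromatic carbon.

Among the compounds with values here, one measured step bears on this: a step that the two limits leave unreadable from compound 1 to compound 2. That step also swaps a sulfanyl group and an amino group at the same place, but it has no readable size, so no size can be carried over from it. The expectation rests instead on compound 1, which carries a sulfanyl group too and reads > 20000 nM, a limit. No direction of change is therefore expected, and the expected result is a step that the limit leaves unreadable from compound 2 to compound 3. For compound 3 the estimated value is 25000 nM, with an expected range of 10000 nM to 60000 nM.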

Compound 3, half-maximal cytotoxic concentration: > 20000 nM
Compound 3: only a limit was reported (the forecaster's own chance of this, stated with the estimate: 70%); the middle value lies beyond the limit too.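

No new step can be read: compound 1, compound 2 and compound 3 all stand at limits of the assay and not at numbers, so the steps among them cannot be read. Still open, on these data alone, is how much of each compound is tolerated in this assay, and whether swapping the group on this aromatic carbon changes that at all.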